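From Methyl to Methoxy on the Shared Core

The source may hold more compounds than are shown below. What is called first, only, known or untested is meant among the compounds shown, and "the series" means these compounds.

Measured so far:
compound 1 `Cc1cccc(-c2n[nH]cc2N2CCCNCC2)c1` — 816 nM
compound 2 `Fc1ccc(-c2n[nH]cc2N2CCCNCC2)cc1` — 1810 nM

In an assay on isolated protein for binding affinity to 5-hydroxytryptamine receptor 3A (Homo sapiens) (on this read-out lower numbers stand for stronger inhibition and higher numbers for weaker inhibition), compound 1 gives 816 nM, the lowest of the two numbers shown. Compound 2 gives 1810 nM, a higher number that lies beyond the scatter. Compound 3 `COc1cccc(-c2n[nH]cc2N2CCCNCC2)c1` differs from compound 1 by methoxy in place of methyl on an aromatic carbon. For the measured compounds named here, no measured pair shows this change, so the expected step from compound 1 to compound 3 is a 1.3-fold higher number from compound 1 to compound 3 (0.13 log units; within the scatter), a small shift that may stay within the scatter. Compound 3 is therefore estimated at 1100 nM, within 400 nM to 3000 nM.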

Compound 3, inhibition constant: 1030 nM
Beside the measured number, compound 3's estimate is 1.1-fold (0.03 log units) above it, and the stated range covers the measured number.
By their numbers in this assay, from the lowest: compounds 1, 3 and 2 (each within the scatter of the next, the first and the last beyond it).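

In this assay, methoxy in place of methyl on an aromatic carbon, meta to a large group, gives a 1.3-fold higher number from compound 1 to compound 3 (0.10 log units; within the scatter) and so stays within the scatter. For the compounds shown here, this is the first measured change at this position, and it shows that the number can stay within the scatter when methoxy, with its hydrogen-bond acceptor, enters there. Nothing available here accounts for this result. The compounds shown leave open how an amine, a carboxylic acid or a longer chain on this same aromatic carbon would read.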